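Aryl variation on the shared core: expectation for compound 3

The compounds below may be only part of what the source reports. "The series", "measured", "known", "first", "only" and "open" are said of these compounds alone.

Measured compounds in this assay:
compound 1 `Cc1cc(NC(=O)Cn2nnc(-c3ccccn3)n2)n(C2CCCCC2)n1` 14600 nM
compound 2 `Cc1cc(NC(=O)Cn2nnc(-c3ccnc(F)c3)n2)n(C2CCCCC2)n1` 441 nM

In an assay on HEK293 cells for activation of Kir3.1/Kir3.2 (Homo sapiens), read by thallium flux (a lower number here means that less compound is needed, a higher number that more compound is needed for the effect), compound 1 gives 14600 nM, and compound 2 gives 441 nM. For the measured compounds named here, the single step between them, a 33-fold lower number from compound 1 to compound 2 (1.52 log units; beyond the scatter), is the only measured change at the aryl position on the shared core. Going by the values given here, compound 2 thus stands at the lowest of the two numbers, with compound 1 as its only neighbour, separated by that step.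

Compound 3 `COc1cccc(-c2nnn(CC(=O)Nc3cc(C)nn3C3CCCCC3)n2)c1` is not yet measured. It differs from compound 2 by 3-methoxyphenyl in place of 2-fluoropyridin-4-yl on an aromatic carbon. The step from compound 1 to compound 2 bears on it in so far as it concerns the same position, but that step exchanged one nitrogen-containing ring for another, whereas the present change removes the ring nitrogen and brings a methoxy group. Among the compounds with values here, no measured pair shows an aryl of carbon only at this position, so the direction is not fixed by the data. Compound 3 is expected to give 2500 nM, within 500 nM to 12000 nM. This estimate implies a 5.7-fold higher number from compound 2 to compound 3 (0.75 log units; beyond the scatter), a step toward a higher number beyond the scatter, held with low confidence.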

Compound 3, half-maximal effective concentration: 117 nM
Compound 3: middle estimate off by 21-fold (1.33 log units), on the high side, and the stated range ends above it.
By their numbers in this assay, from the lowest: compound 3; then compound 2; then compound 1.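

In this assay the position on the five-membered aromatic ring with 4 nitrogen tolerates an aryl of carbon only: 3-methoxyphenyl gives a 3.8-fold lower number from compound 2 to compound 3 (0.58 log units; beyond the scatter) and, against pyridin-2-yl, a 120-fold lower number from compound 1 to compound 3 (2.10 log units; beyond the scatter) in the same series. Among these three compounds a ring nitrogen in the aryl is therefore not needed for the lowest number, and the aryl group alone spans a wide range on the shared core, with compound 3 lowest, then compound 2, then compound 1. No measurement on hand accounts for either step.

The step from 2-fluoropyridin-4-yl to 3-methoxyphenyl removes the ring nitrogen and the fluorine and brings in the methoxy group all at once, so these compounds do not separate the contribution of the carbon-only ring from that of the methoxy group. Open too, going by these compounds, is how a plain phenyl ring would compare, and whether an ethoxy group or an amine in place of the methoxy group would hold, lower or raise the number.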